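A few compounds are considered here, and "the series" means these few. Any claim that something is new, unique, unknown or untested is made for them only; others in the source may bear on it.

Three compounds have been measured in a functional assay on cells for antagonist activity at Glucagon receptor (Homo sapiens), read by cAMP accumulation, in the presence of a further agent that is not named here; on this read-out higher numbers stand for weaker inhibition and lower numbers for stronger inhibition:

Compound 1, `CCCC(Nc1ccc(-n2cc(C(F)(F)F)cn2)nc1)c1ccc(C(=O)NCCC(=O)O)cc1`, gives 1300 nM.
Compound 2, `O=C(O)CCNC(=O)c1ccc(C(Oc2ccc(-n3cc(C(F)(F)F)cn3)cc2)C2CC2)cc1`, gives 15000 nM.
Compound 3, `CCCC(Oc1ccc(-n2cc3ccccc3n2)cc1)c1ccc(C(=O)NCCC(=O)O)cc1`, gives 2000 nM.

Compound 3 holds the second highest of the three numbers. Its nearest neighbour is compound 1, whose number is lower, but the gap between the two lies within the scatter of this assay, so the two cannot be told apart. Compound 2 stands furthest away, with a higher number that lies beyond the scatter, so compound 2 is the weaker inhibitor of that pair.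

The next compound, compound 4, `CCCC(Oc1ccc(-n2cc(C#N)cn2)cc1)c1ccc(C(=O)NCCC(=O)O)cc1`, is not yet measured. It differs from compound 3 in one place: 4-cyano-1H-pyrazol-1-yl in place of 2H-indazol-2-yl on an aromatic carbon. Among the compounds with values here, no pair of measured compounds differs by exactly this change, so there is no measured step to lean on. With compound 1 and compound 3 sitting close together despite different groups at this position, the expected step from compound 3 to compound 4 is a 1.3-fold lower number from compound 3 to compound 4 (0.12 log units; within the scatter), pointing a little towards stronger inhibition, but not beyond the scatter. Compound 4 is therefore estimated at 1500 nM, with a likely range from 500 nM to 5000 nM.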

Compound 4, antagonist equilibrium constant: > 50000 nM
Compound 4: only a limit was reported (the forecaster's own chance of this, stated with the estimate: 5%); middle value at least 33-fold (1.52 log units) from the limit.
By their numbers in this assay, from the lowest: compounds 1 and 3 (each within the scatter of the next); then compound 2. At a limit, above all of these: compound 4.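

This position is far from indifferent: putting 4-cyano-1H-pyrazol-1-yl in place of 2H-indazol-2-yl, with the rest of the molecule unchanged, gives an at least 25-fold higher number from compound 3 to compound 4 (1.39 log units; beyond the scatter) in this assay and is a large change beyond the scatter. Compound 4 gives > 50000 nM as a limit of the assay, not as a number, so the step has a known lower bound but no known full size. Among the earlier compounds no two differed in one place only, so this pair is the first direct reading of the position, and it shows that exchanging one aromatic group for another here can cost nearly all measurable inhibition.

The change does two things at once, removing the six-membered aromatic ring of carbon only and adding a nitrile, and this single pair cannot separate the two. A plain pyrazol-1-yl with only hydrogen on the ring, or a pyrazole carrying a methyl group or a chlorine atom where the nitrile sits, would be needed to show which part of the swap goes with the loss.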